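Mirror image of compound 2: what to expect

The compounds below may be only part of what the source reports. "The series", "measured", "known", "first", "only" and "open" are said of these compounds alone.

Measured so far:
Compound 1 `CSCC[C@H](NC(=O)c1ccc(OC[C@@H]2COc3ncccc3O2)cc1-c1ccccc1C)C(=O)O`: 58800 nM
Compound 2 `CSCC[C@H](NC(=O)c1ccc(OC[C@H]2COc3ncccc3O2)cc1-c1ccccc1C)C(=O)O`: 158000 nM

In a functional assay (Homo sapiens) for antiproliferative activity (a higher number here means a weaker inhibitor, a lower number a stronger inhibitor), compound 2 gives 158000 nM, the higher of the two numbers, which makes it the weaker of the pair. The next molecule is compound 3 `CSCC[C@@H](NC(=O)c1ccc(OC[C@@H]2COc3ncccc3O2)cc1-c1ccccc1C)C(=O)O`, and it relates to compound 2 as follows: the two compounds have the same atoms and bonds and differ only in configuration as drawn: 2 of 2 stereo elements differ (all stereocentres are inverted: mirror images); a stereocentre at a saturated chain carbon is drawn S in compound 2 and R in compound 3; a stereocentre at a saturated ring carbon is drawn S in compound 2 and R in compound 3.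

Going by the values given here, only one measured step bears on this change. It is a 2.7-fold higher number from compound 1 to compound 2 (0.43 log units; beyond the scatter), a modest step in which the saturated ring carbon went from R to S. Compound 3 has that ring carbon drawn R again, so the reverse of a 2.7-fold higher number from compound 1 to compound 2 (0.43 log units; beyond the scatter) points to a lower number by a similar amount. Among the compounds with values here, no measured pair shows what inverting the saturated chain carbon does, so its contribution is unknown and could go either way. A small move towards a lower number is therefore expected in this assay, possibly none beyond the scatter. The expected step is a 1.6-fold lower number from compound 2 to compound 3 (0.20 log units; within the scatter). For compound 3 the estimated value is 100000 nM, with an expected range from 35000 nM to 280000 nM.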

Compound 3, half-maximal inhibitory concentration: 16800 nM
For compound 3 the middle estimate is 6.0-fold (0.77 log units) above the measured one; the measured number lies below the stated range.
By their numbers in this assay, from the lowest: compound 3; then compound 1; then compound 2.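

Going by these compounds alone, compounds 1 and 3 share the ring carbon drawn R, so the step of a 3.5-fold lower number from compound 1 to compound 3 (0.54 log units; beyond the scatter) in this assay gives the first reading of the saturated chain carbon on its own, and it shows that this centre matters, with R giving the lower number. The change can be assigned to that one carbon because nothing else separates the pair: the fact that compounds 1 and 3 differ only in the configuration as drawn. The full mirror-image change, a 9.4-fold lower number from compound 2 to compound 3 (0.97 log units; beyond the scatter), is larger than either single inversion shown, as both inversions point towards a lower number, and compound 3 ends up the strongest of the three, with compound 1 in the middle.

Going by these compounds, what stays open is the remaining stereoisomer, with the chain carbon drawn R and the ring carbon drawn S, and so whether the two centres act independently or the effect of one depends on the other. Also open, on these data alone, is whether the preference for the R chain carbon would survive with a methyl ester or a primary amide in place of the carboxylic acid.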